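Hydrogen in place of chloro on compound 2

The source may hold more compounds than are shown below. What is called first, only, known or untested is meant among the compounds shown, and "the series" means these compounds.

Going by the values given here, in a functional assay on NCI-H460 cells (Homo sapiens) for inhibition, read by CCK-8 assay, with a stated time of 72 h, tested at 10 uM (a higher number here means more inhibition of growth at the concentration tested, a lower number less inhibition of growth), compound 1 `CN(C)C(=O)c1cc2cnc(Nc3ccc(NC(=O)C4(C(=O)Nc5cccc(F)c5)CC4)cc3)nc2n1C1CCCC1` gives 98.8% and compound 2 `CN(C)C(=O)c1cc2cnc(Nc3ccc(NC(=O)C4(C(=O)Nc5cccc(Cl)c5)CC4)cc3)nc2n1C1CCCC1` gives 101% with the two within the scatter of each other, so compound 2 stands level with the only other measured compound. Compound 3 `CN(C)C(=O)c1cc2cnc(Nc3ccc(NC(=O)C4(C(=O)Nc5ccccc5)CC4)cc3)nc2n1C1CCCC1` follows from compound 2 through hydrogen in place of chloro on an aromatic carbon with hydrogen in place of chloro on an aromatic carbon, turning 3-chlorophenyl into phenyl. Among the compounds with values here, the one measured step that bears on this is a number 2.2 percentage points higher from compound 1 to compound 2 (within the scatter) and it puts chloro in place of fluoro on an aromatic carbon. Within the data shown here, no measured compound carries hydrogen at that place, so this guidance is indirect. No step beyond the scatter is expected in this assay and the estimated step is a number 5 percentage points lower from compound 2 to compound 3 (within the scatter) on this thin evidence. For compound 3 the estimate is 96% with an expected range from 85% to 103% in this read-out.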

Compound 3, percent growth inhibition at one concentration: 95.9%
Compound 3: the middle estimate sits 0.1 percentage points above what was measured; measured number inside the range.
By their numbers in this assay, from the lowest: compounds 3, 1 and 2 (each within the scatter of the next).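

Hydrogen in place of chloro gives a number 5.1 percentage points lower from compound 2 to compound 3 (within the scatter) in this assay, and hydrogen in place of fluoro gives a number 2.9 percentage points lower from compound 1 to compound 3 (within the scatter). The earlier pair compared only two halogens, whereas these steps show that a halogen on this aromatic carbon is not needed for the phenyl compound to stay within the scatter of both halogenated compounds. No measurement here gives a reason for this flat result.

All three readings lie near full inhibition at a single concentration, so any differences that might appear at lower concentrations cannot be read from these data. From the compounds shown here alone, it also remains open whether a different kind of group at this place, such as methoxy, an amine or a carboxylic acid, would produce a step beyond the scatter in this assay.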